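The source may report more compounds than this note shows. Statements on the series, on what has been measured and on what is new or still open speak of the compounds shown alone.

In a functional assay on HepG2 cells (Homo sapiens) for antiproliferative activity, read by MTT assay, with a stated time of 48 h (a higher number here means a weaker inhibitor, a lower number a stronger inhibitor), three compounds have been measured so far. Compound 1 `COc1ccc(-c2c(Nc3cc(OC)c(OC)c(OC)c3)c3ccccc3oc2=O)cc1` gives 77300 nM. Compound 2 `COc1ccc(-c2c(Nc3ccc(F)cc3)c3ccc(OC)cc3oc2=O)cc1` gives > 100000 nM, which is a limit of the assay and not a number. Compound 3 `CCOc1ccc(Nc2c(-c3ccc(OC)cc3)c(=O)oc3cc(OC)ccc23)cc1` gives 31200 nM, the lower of the two actual numbers, and its gap to compound 1 lies beyond the scatter.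

Compound 4 `COc1ccc(-c2c(Nc3cccc(C(F)(F)F)c3)c3ccc(OC)cc3oc2=O)cc1` now follows, with 3-(trifluoromethyl)phenyl in place of 4-ethoxyphenyl on a nitrogen on an aromatic ring. For the measured compounds named here, one measured step bears on this change, an at least 3.2-fold lower number from compound 2 to compound 3 (0.50 log units; beyond the scatter), where ethoxy in place of fluoro on an aromatic carbon brought the number down by a margin beyond the scatter. Since compound 4 also lacks the ethoxy group, that step, read in reverse, points towards a higher number. Going by the values given here, it is only a loose guide, as trifluoromethyl is a different group from fluoro and no measured step covers it. A modest move towards weaker inhibition is therefore expected in this assay. The expected step is a 2.2-fold higher number from compound 3 to compound 4 (0.35 log units; beyond the scatter). For compound 4 the estimated value is 70000 nM, with an expected range of 30000 nM to 100000 nM.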

Compound 4, half-maximal inhibitory concentration: 57300 nM
Estimate against measurement, compound 4: 1.2-fold (0.09 log units) above; the measured number falls inside the stated range.
By their numbers in this assay, from the lowest: compounds 3, 4 and 1 (each within the scatter of the next, the first and the last beyond it). At a limit, above all of these: compound 2.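

In this assay, 3-(trifluoromethyl)phenyl in place of 4-ethoxyphenyl on a nitrogen on an aromatic ring gives a 1.8-fold higher number from compound 3 to compound 4 (0.26 log units; within the scatter), so compound 3 and compound 4 cannot be told apart at this position, although their groups differ. Compound 2 stands at > 100000 nM, which is a limit of the assay and not a number. Compound 4 lacks the ethoxy group and still gives an actual number, so that group is not needed for a reading under the limit, but the comparison with the 4-fluorophenyl compound, an at least 1.7-fold lower number from compound 2 to compound 4 (0.24 log units; that floor lies within the scatter), does not establish a real difference, and it rests on a limit: the limit of > 100000 nM in this assay, at which 1 of the 4 values shown sits.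

The compounds shown leave open how an amine, a carboxylic acid or a longer chain on this aromatic ring would read in this assay. They also leave open whether 3-(trifluoromethyl)phenyl and 4-ethoxyphenyl would stay as close on the core of compound 1, which differs from compound 3 and compound 4 in more than one place.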